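Replacing a bulky amine by fluorine on the benzylic ring

The source may report more compounds than this note shows. Statements on the series, on what has been measured and on what is new or still open speak of the compounds shown alone.

Compound 1 `CCC1CCN(c2cc(C(F)(F)F)ccc2CNC(=O)C(C)c2ccc(NS(C)(=O)=O)c(F)c2)CC1` is tested in an assay on CHO cells for antagonist activity at transient receptor potential cation channel subfamily V member 1 (Homo sapiens), read by FLIPR (a lower number here means a stronger inhibitor, a higher number a weaker inhibitor), where compound 1 gives 0.7 nM. Among the three measured compounds it stands with the highest number. Its nearest neighbour, compound 2 `CC(C(=O)NCc1ccc(C(F)(F)F)cc1OC1CCCC1)c1ccc(NS(C)(=O)=O)c(F)c1`, gives 0.6 nM, and the step of a 1.2-fold lower number from compound 1 to compound 2 (0.07 log units; within the scatter) shows that a cyclopentyloxy group can take the place of the 4-ethylpiperidin-1-yl group without a change beyond the scatter. Compound 3 `C[C@H](C(=O)NCc1ccc(C(F)(F)F)cc1SC1CCCCC1)c1ccc(NS(C)(=O)=O)c(F)c1` gives 0.3 nM, a number that lies beyond the scatter below that of compound 1.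

Compound 4 `CC(C(=O)NCc1ccc(C(F)(F)F)cc1F)c1ccc(NS(C)(=O)=O)c(F)c1` is the next compound to be measured. The difference from compound 1 is fluoro in place of 4-ethylpiperidin-1-yl on an aromatic carbon. For the measured compounds named here, no measured step bears directly on this change: the one documented step swaps one large group for another of similar size, whereas here a group of 8 heavy atoms is reduced to a single fluorine, ortho to a large group and meta to the trifluoromethyl group. With the two measured replacements both keeping a substantial group at this position, the loss of that group is expected to cost potency, a step of a 7.1-fold higher number from compound 1 to compound 4 (0.85 log units; beyond the scatter) being expected in this assay. Compound 4 is therefore estimated at 5 nM, with a range from 1.5 nM to 20 nM.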

Compound 4, inhibition constant: 68.7 nM
Compound 4: the middle estimate sits 14-fold (1.14 log units) below what was measured; the measured number lies above the stated range.
By their numbers in this assay, from the lowest: compounds 3, 2 and 1 (each within the scatter of the next, the first and the last beyond it); then compound 4.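

In this assay this position proves far from indifferent to what stands on it. The earlier step showed only that cyclopentyloxy can take the place of 4-ethylpiperidin-1-yl without a change beyond the scatter, whereas fluoro gives large losses against both groups (a 98-fold higher number from compound 1 to compound 4 (1.99 log units; beyond the scatter) and a 110-fold higher number from compound 2 to compound 4 (2.06 log units; beyond the scatter)), so the low numbers of compound 1 and compound 2 depend on keeping one of these two larger groups on this aromatic carbon rather than a single fluorine atom. The compounds shown offer no measurement that explains this loss.

What remains open is how the number changes between these extremes, since nothing shown lies between a single fluorine atom and the two larger groups: a methoxy or ethoxy group, or a small amine such as dimethylamino, could show whether part of the potency returns with only a few added atoms. A compound with plain hydrogen at this place would also show whether fluoro itself costs potency or merely fails to provide what the larger groups provide.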